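Cytotoxicity notes: relocating the trifluoromethyl group

The source may report more compounds than this note shows. Statements on the series, on what has been measured and on what is new or still open speak of the compounds shown alone.

Measured in an ADME assay on MT4 cells (Homo sapiens) for cytotoxicity, read by MTT assay, with a stated time of 3 days; on this read-out lower numbers stand for higher toxicity in this test and higher numbers for lower toxicity in this test:
- compound 1 `CC(=O)Oc1ccc(CN(C(=O)COC(=O)c2ccc([N+](=O)[O-])o2)C(C)(C)C)cc1`: > 100000 nM (a limit)
- compound 2 `CC(C)(C)N(Cc1cccc(C(F)(F)F)c1)C(=O)COC(=O)c1ccc([N+](=O)[O-])o1`: > 100000 nM (a limit)

Compound 2 gives only a limit, > 100000 nM, and no number. Compound 3 `CC(C)(C)N(Cc1ccccc1C(F)(F)F)C(=O)COC(=O)c1ccc([N+](=O)[O-])o1` carries 2-(trifluoromethyl)phenyl in place of 3-(trifluoromethyl)phenyl on a saturated chain carbon bound to an amide-type nitrogen. For the measured compounds named here, the one measured step is a step that the two limits leave unreadable from compound 1 to compound 2, so it offers no size to carry over. With the limit of > 100000 nM in this assay, at which 2 of the 2 values shown sit, no step beyond the scatter is expected in this assay, and no direction can be given. The expected size is a number no higher from compound 2 to compound 3 (the limit leaves the size open). For compound 3 the estimate is 100000 nM, with an expected range of 40000 nM to 250000 nM.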

Compound 3, half-maximal cytotoxic concentration: 95000 nM
Beside the measured number, compound 3's estimate is 1.1-fold (0.02 log units) above it; measured number inside the range.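

For the compounds shown here, compound 3 gives the first actual number in this assay, and the two steps now have a floor: an at least 1.0-fold lower number from compound 2 to compound 3 (0.02 log units; that floor lies within the scatter) for 2-(trifluoromethyl)phenyl in place of 3-(trifluoromethyl)phenyl, and an at least 1.0-fold lower number from compound 1 to compound 3 (0.02 log units; that floor lies within the scatter) for 2-(trifluoromethyl)phenyl in place of 4-acetoxyphenyl. Neither floor shows a change at this position beyond the scatter, and the series still sits largely at a limit of the test: the limit of > 100000 nM in this assay, at which 2 of the 3 values shown sit.

On these data alone, the step from compound 1 to compound 2 remains unreadable, and how far compound 3 truly lies from either stays open. Also open, as far as these compounds go, is whether an amine or a carboxylic acid on the phenyl ring would give a clearly lower number.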